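Series notes: a diethylamino addition on compound 2

A few compounds are considered here, and "the series" means these few. Any claim that something is new, unique, unknown or untested is made for them only; others in the source may bear on it.

Compound 2, `C/C=C/C(=O)NC/C=C/c1cc(OCCc2ccc(F)cc2)cc(O)c1C(=O)OC(C)C`, is tested in a functional assay on MV4-11 cells (Homo sapiens) for antiproliferative activity, read by luminescence, with a stated time of 72 h; a higher number here means a weaker inhibitor, a lower number a stronger inhibitor. There compound 2 gives > 10000 nM, which is a limit of the assay and not a number. Compound 3, `COc1cc(O)c(C(=O)OC(C)C)c(/C=C/CNC(C)=O)c1`, also ends at a limit; in this assay compound 3 gives > 10000 nM. Within the data shown here, compound 1, `COc1cc(O)c(C(=O)OC(C)C)c(/C=C/CN2C(=O)C=CC2=O)c1`, is the only one with a number, 1730 nM in this assay. Among the measured compounds shown here, the single measured step, an at least 5.7-fold higher number from compound 1 to compound 3 (0.76 log units; beyond the scatter), sits at the same kind of place as the present change but swaps a different group, so it bears on compound 4 only loosely; it does show that a change on that chain carbon can move the number beyond the scatter. The the limit of > 10000 nM in this assay, at which 2 of the 3 values shown sit, leaves compound 2 without a numerical anchor. Compound 4, `CCN(CC)C/C=C/C(=O)NC/C=C/c1cc(OCCc2ccc(F)cc2)cc(O)c1C(=O)OC(C)C`, differs from compound 2 by diethylamino in place of hydrogen on a saturated chain carbon bound to a double-bonded chain carbon. The expected step of an at least 2.0-fold lower number from compound 2 to compound 4 (0.30 log units; that floor lies within the scatter) is toward a lower number, though the limit makes its size uncertain. For compound 4 the estimate in this assay is 5000 nM, within 1500 nM to 20000 nM.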

Compound 4, half-maximal inhibitory concentration: 4040 nM
Compound 4: the middle estimate sits 1.2-fold (0.09 log units) above what was measured; low and high end bracket the measured number.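

Diethylamino in place of hydrogen on a saturated chain carbon bound to a double-bonded chain carbon gives, in this assay, an at least 2.4-fold lower number from compound 2 to compound 4 (0.39 log units; beyond the scatter). Unlike the earlier step on a chain carbon, which swaps one group for another on a different core, this change leaves the rest of compound 2 untouched and still moves the number beyond the scatter. Compound 2 gives > 10000 nM, which is a limit of the assay and not a number, so the step is known only as a floor because of that limit: the limit of > 10000 nM in this assay, at which 2 of the 4 values shown sit.

Going by these compounds, it remains open whether the step depends on the amine itself or on added size at that carbon, which a butyl chain, a dimethylamino or a morpholine at the same place would help separate. Also open, on these data alone, is whether diethylamino would have a similar effect on the core of compound 3.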